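This account rests on a few compounds, and the source may have more. Where it says the series, first, only, none or still open, it means among the compounds named here.

Compound 3 `O=C(c1ccc(Cl)cc1)n1c(-c2cn(-c3ccccc3)nc2-c2ccc(C(F)(F)F)cc2)nc2ccccc21` is measured in an ADME assay on HEK-293T cells (Homo sapiens) for cytotoxicity, read by MTT assay, with a stated time of 24 h (on this read-out lower numbers stand for higher toxicity in this test and higher numbers for lower toxicity in this test), at 181000 nM. Compound 1 `Cc1cccc(C(=O)n2c(-c3cn(-c4ccccc4)nc3-c3ccc(C(F)(F)F)cc3)nc3ccccc32)c1` gives 154000 nM in this assay, and the step of a 1.2-fold higher number from compound 1 to compound 3 (0.07 log units; within the scatter) separates the two. Within the data shown here, compound 2 `Cc1ccc(C(=O)n2c(-c3cn(-c4ccccc4)nc3-c3ccc(F)cc3)nc3ccccc32)cn1` gives 137000 nM in this assay, a number within the usual scatter of the one for compound 3, so the three compounds cannot be told apart on this read-out. Compound 4 `Cc1ccc(C(=O)n2c(-c3cn(-c4ccccc4)nc3-c3ccc(C(F)(F)F)cc3)nc3ccccc32)cn1` has not yet been measured. It differs from compound 3 by 6-methylpyridin-3-yl in place of 4-chlorophenyl on a carbonyl carbon. Among the measured compounds shown here, the only measured step at the same place is a 1.2-fold higher number from compound 1 to compound 3 (0.07 log units; within the scatter), which stayed within the scatter, and compound 2, which also carries the 6-methylpyridin-3-yl group on the carbonyl carbon, sits within the scatter of compound 3 as well. Compound 4 is therefore expected to show no step beyond the scatter, and its estimated step is a 1.2-fold lower number from compound 3 to compound 4 (0.08 log units; within the scatter). Compound 4 is estimated at 150000 nM, with a range from 85000 nM to 260000 nM.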

Compound 4, half-maximal cytotoxic concentration: 153000 nM
Estimate against measurement, compound 4: 1.0-fold (0.01 log units) below, within the range that was stated.
By their numbers in this assay, from the lowest: compounds 2, 4, 1 and 3 (each within the scatter of the next).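

In this assay the 6-methylpyridin-3-yl group on the carbonyl carbon can now be set against two other groups with the trifluoromethyl side of the molecule held the same: the change from 4-chlorophenyl gives a 1.2-fold lower number from compound 3 to compound 4 (0.07 log units; within the scatter) and the change from 3-methylphenyl gives a 1.0-fold lower number from compound 1 to compound 4 (0.00 log units; within the scatter) as steps that show no difference at this position. Among these compounds, a second place can also be read for the first time, as trifluoromethyl in place of fluoro on an aromatic carbon gives a 1.1-fold higher number from compound 2 to compound 4 (0.05 log units; within the scatter) and so adds a step that stays inside the scatter as well. Nothing at hand explains why these numbers stay together.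

Still open, going by these compounds, is whether a carboxylic acid or an amine on the group at the carbonyl carbon would give a step beyond the scatter. The same question stands for a simple acetyl group there, which would carry no aromatic ring at this place.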